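Swapping hydroxy for fluoro on compound 1

This account rests on a few compounds, and the source may have more. Where it says the series, first, only, none or still open, it means among the compounds named here.

compound 1 `Oc1ccc(-c2nc3cc(C(F)(F)F)ccc3[nH]2)cc1`: 51000 nM
compound 2 `COc1ccc(-c2nc3cc(C(F)(F)F)ccc3[nH]2)c(OC)c1OC`: > 100000 nM
compound 3 `COc1ccc(-c2nc3cc(C(F)(F)F)ccc3[nH]2)c([N+](=O)[O-])c1`: 55000 nM

In an ADME assay on MDBK cells (Bos taurus) for cytotoxicity, read by MTT assay, with a stated time of 96 h (on this read-out lower numbers stand for higher toxicity in this test and higher numbers for lower toxicity in this test), compound 1 gives 51000 nM, and compound 3 gives 55000 nM. These two numbers lie within the usual scatter of each other, so compound 1 shares its place on the scale with compound 3. Compound 2 gives only a limit of the assay, > 100000 nM.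

The next compound to be tested is compound 4 `Fc1ccc(-c2nc3cc(C(F)(F)F)ccc3[nH]2)cc1`. It keeps the core of compound 1 and carries fluoro in place of hydroxy on an aromatic carbon, para to a large group (fluoro in place of hydroxy on an aromatic carbon). Going by the values given here, no measured pair of compounds shows this change on its own, so the expectation rests on thin ground. Compound 1 at 51000 nM and compound 3 at 55000 nM carry different groups yet give matching numbers, although compound 2 goes against any such pattern. In this assay, no step beyond the scatter is expected, in either direction. The estimated step is a 1.2-fold higher number from compound 1 to compound 4 (0.07 log units; within the scatter). Compound 4 is expected to give 60000 nM, within an estimated range of 25000 nM to 100000 nM.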

Compound 4, half-maximal cytotoxic concentration: 19000 nM
For compound 4 the middle estimate is 3.2-fold (0.50 log units) above the measured one; the whole stated range lies above it.
By their numbers in this assay, from the lowest: compound 4; then compounds 1 and 3 (each within the scatter of the next). At a limit, above all of these: compound 2.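

In this assay, going by these compounds alone, swapping hydroxy for fluoro on the aromatic carbon para to a large group gives the first readable step for a single change: a 2.7-fold lower number from compound 1 to compound 4 (0.43 log units; beyond the scatter). The earlier compounds shown here differ from one another in more than one place, so none of them could show that this position can move the read-out, here toward higher toxicity in this test. Compound 2 gives a limit and not a number, so it offers no measured value for comparison: the limit of > 100000 nM in this assay, at which 1 of the 4 values shown sits.

This single pair cannot separate the loss of hydroxy from the arrival of fluoro, and it does not say why the number moves. It also leaves open whether another group at this position, such as an amine or a chloro group, would follow compound 4 or compound 1.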